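The source may report more compounds than this note shows. Statements on the series, on what has been measured and on what is new or still open speak of the compounds shown alone.

Compound 1 `O=C(c1ccccc1)N1CCC(C(=O)N2N=CCC2c2ccccc2)CC1` gives 1.72 h
Compound 2 `CCC(=O)N1CCC(C(=O)N2N=CCC2c2ccccc2)CC1` gives > 2.75 h, a limit
Compound 3 `O=C(c1c[nH]nn1)N1CCC(C(=O)N2N=CCC2c2ccccc2)CC1` gives > 2.75 h, a limit

These values come from an ADME assay on microsomes (Homo sapiens) for metabolic stability; on this read-out lower numbers stand for a shorter-lived compound and higher numbers for a longer-lived compound. Compound 3 has no exact number and stands at the limit of > 2.75 h in this assay, at which 2 of the 3 values shown sit. Compound 4 `O=C(c1cocn1)N1CCC(C(=O)N2N=CCC2c2ccccc2)CC1` differs from it by 1,3-oxazol-4-yl in place of 1H-1,2,3-triazol-4-yl on a carbonyl carbon, with 1,3-oxazol-4-yl in place of 1H-1,2,3-triazol-4-yl on a carbonyl carbon. The nearest measured steps are an at least 1.5-fold higher number from compound 1 to compound 3 (0.20 log units; that floor lies within the scatter) and an at least 1.5-fold higher number from compound 1 to compound 2 (0.20 log units; that floor lies within the scatter). The third is a step that the two limits leave unreadable from compound 2 to compound 3. None of them exchanges one five-membered aromatic ring for another, so no step beyond the scatter is expected in this assay. The expected step is an at least 1.0-fold lower number from compound 3 to compound 4 (0.00 log units; that floor lies within the scatter). For compound 4 the estimate is 2.7 h, with an expected range from 1.5 h to 4.5 h.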

Compound 4, half-life: > 2.75 h
Compound 4: only a limit was reported; the forecaster's own chance of this, stated with the estimate: 55%; middle value at least 1.0-fold (0.00 log units) from the limit.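

In this assay compound 4 gives > 2.75 h, which is a limit. Against the phenyl group, 1,3-oxazol-4-yl gives an at least 1.5-fold higher number from compound 1 to compound 4 (0.20 log units; that floor lies within the scatter). Giving up the hydrogen-bond donor of 1H-1,2,3-triazol-4-yl on this carbonyl carbon does not take the compound off the shared limit: the limit of > 2.75 h in this assay, at which 3 of the 4 values shown sit.

The steps among compound 2, compound 3 and compound 4 cannot be read, as all three values are limits. From the compounds shown here alone, what an amine or a carboxylic acid at this place would give in this assay remains open.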